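Butoxy in place of ethyl on an 8-aryl xanthine

The source may report more compounds than this note shows. Statements on the series, on what has been measured and on what is new or still open speak of the compounds shown alone.

Of the compounds shown here, two sharing one core have been measured in an assay for binding affinity to adenosine receptor A1 (Bos taurus); on this read-out higher numbers stand for weaker inhibition and lower numbers for stronger inhibition. Compound 1 `COc1cc(OC)cc(-c2nc3c(=O)n(C)c(=O)n(C)c3[nH]2)c1` carries two methoxy groups on its aromatic ring and in this assay compound 1 gives 500 nM. Compound 2 `CCc1ccc(-c2nc3c(=O)n(C)c(=O)n(C)c3[nH]2)cc1` carries a single ethyl group, and in this assay compound 2 gives 0.8 nM. Compound 2 thus stands at the lower of the two numbers, and the gap to compound 1 lies well beyond the scatter, so compound 2 binds the stronger of the two.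

Compound 3 `CCCCOc1ccc(-c2nc3c(=O)n(C)c(=O)n(C)c3[nH]2)cc1` is the next member to be studied. It differs from compound 2 in one place: butoxy in place of ethyl on an aromatic carbon. For the measured compounds named here, no measured pair shows this kind of change, so the size of the step cannot be read from earlier data. Since the shared core already reaches a very low number in compound 2, a modest weakening is expected, with the step from compound 2 to compound 3 estimated as a 3.8-fold higher number from compound 2 to compound 3 (0.57 log units; beyond the scatter). For compound 3 the expected value in this assay is 3 nM, within a range of 0.5 nM to 20 nM.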

Compound 3, half-maximal inhibitory concentration: 4 nM
Compound 3: the middle estimate sits 1.3-fold (0.12 log units) below what was measured, within the range that was stated.
By their numbers in this assay, from the lowest: compound 2; then compound 3; then compound 1.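

For the compounds shown here, putting butoxy in place of ethyl on this aromatic carbon gives a 5.0-fold higher number from compound 2 to compound 3 (0.70 log units; beyond the scatter) in this assay and marks the first single change that can be read. The step is modest but beyond the scatter, so the change does register, yet a larger group that also brings a hydrogen-bond acceptor is accepted at this place with only a limited loss, and compound 3 gives 4 nM here. No measurement at hand explains this step, and this one pair cannot tell the part played by the added oxygen from that of the longer chain.

The compounds shown leave open how the oxygen and the chain each contribute, since butoxy differs from ethyl in both respects at once: a plain butyl group would keep a long chain without the oxygen, while an ethoxy group would keep the oxygen with a shorter chain. They also leave open how far this place tolerates quite different groups, such as an amine or a carboxylic acid, or a chain longer than butoxy.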